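Cyclobutyl Amide of the Benzyl Pyridinone Core

A few compounds are considered here, and "the series" means these few. Any claim that something is new, unique, unknown or untested is made for them only; others in the source may bear on it.

The measured compounds:
compound 1 `CNC(=O)c1cc(C(=O)NCCC2CCOCC2)cn(Cc2ccccc2)c1=O` with 3.6
compound 2 `CNC(=O)c1cc(C(=O)NC2CC2)cn(Cc2cccc3[nH]ccc23)c1=O` with 2.9

Among the compounds with values here, in a physicochemical assay for lipophilicity, at pH 7.4 (a higher number here means a more lipophilic compound, a lower number a more polar compound), compound 1 gives 3.6, the higher of the two numbers known so far. Compound 2 gives 2.9 in this assay, a value that sits beyond the usual scatter below compound 1, though the two structures differ in more than one place, so nothing follows for any single change from this pair.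

The next compound is compound 3 `CNC(=O)c1cc(C(=O)NC2CCC2)cn(Cc2ccccc2)c1=O`. It differs from compound 1 in one place: cyclobutyl in place of 2-(oxan-4-yl)ethyl on an amide-type nitrogen. Within the data shown here, no measured pair shows this change on its own. Cyclobutyl carries fewer heavy atoms and no hydrogen-bond acceptor, while 2-(oxan-4-yl)ethyl carries more carbon but also one oxygen; the two effects are expected to largely offset. The expected step of a number 0.30 log units lower from compound 1 to compound 3 (within the scatter) is a small decrease, close to the edge of the scatter. For compound 3 the estimate in this assay is 3.3, with a range from 2.8 to 3.8.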

Compound 3, distribution coefficient: 3.8
Beside the measured number, compound 3's estimate is 0.50 log units below it, and the stated range covers the measured number.
By their numbers in this assay, from the lowest: compound 2; then compounds 1 and 3 (each within the scatter of the next).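

Within the data shown here, on the amide-type nitrogen, the first direct comparison in this assay shows that exchanging 2-(oxan-4-yl)ethyl for cyclobutyl gives a number 0.20 log units higher from compound 1 to compound 3 (within the scatter). The two compounds therefore cannot be told apart in this measurement, although the entering group has 4 heavy atoms and no hydrogen-bond acceptor, while the leaving group has 8 heavy atoms and 1 hydrogen-bond acceptor. Nothing available accounts for this close agreement, which rests on a single pair.

Still open, from the compounds shown here alone, is whether this insensitivity extends to other groups at the same nitrogen, such as an amine, a carboxylic acid or a longer carbon chain. It is equally unknown whether the same exchange would read alike on a different substituent elsewhere on the shared core.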